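Pyridyl shift on the branched benzyl analogue

The source may hold more compounds than are shown below. What is called first, only, known or untested is meant among the compounds shown, and "the series" means these compounds.

Going by the values given here, compound 3 `CC(c1ccccc1)N1C(=O)/C(=C\c2cccnc2)c2ccccc21` holds the lowest of the three numbers so far in a functional assay on HL-60 cells (Homo sapiens) for cytotoxicity, read by MTT assay, with a stated time of 72 h, tested at 5 uM (a lower number here means a stronger effect, a higher number a weaker effect of the compound at the concentration tested), giving 19.6%. Compound 1 `O=C1/C(=C\c2cccnc2)c2ccccc2N1Cc1ccccc1` gives 25.4% in this assay, and compound 2 `O=C1/C(=C\c2ccccn2)c2ccccc2N1Cc1ccccc1` gives 24.7%; both gaps to compound 3 are within the scatter, so the three cannot be placed in order. Compound 4 `CC(c1ccccc1)N1C(=O)/C(=C\c2ccccn2)c2ccccc21` differs from compound 3 by pyridin-2-yl in place of pyridin-3-yl on a double-bonded chain carbon bound to a double-bonded ring carbon. The same change, pyridin-2-yl in place of pyridin-3-yl on a double-bonded chain carbon bound to a double-bonded ring carbon, was measured once, from compound 1 to compound 2: a number 0.7 percentage points lower from compound 1 to compound 2 (within the scatter). The other step, a number 5.8 percentage points lower from compound 1 to compound 3 (within the scatter), is a different change and only shows that the methyl-bearing compound sits where the others do. With one relevant precedent within the scatter, no movement beyond the scatter is expected for compound 4: a number 0.6 percentage points lower from compound 3 to compound 4 (within the scatter). Compound 4 is therefore estimated at 19% in this assay, with a range from 9% to 29%.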

Compound 4, a percentage reported as activity, at one concentration (the size of the read-out at that concentration, not a potency): 55.7%
For compound 4 the middle estimate is 36.7 percentage points below the measured one; measured number outside the range, above it.
By their numbers in this assay, from the lowest: compounds 3, 2 and 1 (each within the scatter of the next); then compound 4.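

In this assay, pyridin-2-yl in place of pyridin-3-yl on the double-bonded chain carbon gives a number 36.1 percentage points higher from compound 3 to compound 4 (beyond the scatter), so the outcome of this change depends on the core that carries it: the same change on two cores in this assay, a number 0.7 percentage points lower (within the scatter) from compound 1 to compound 2 and a number 36.1 percentage points higher (beyond the scatter) from compound 3 to compound 4, 36.8 percentage points apart, beyond the scatter of two such steps

Read the other way, methyl in place of hydrogen on the saturated chain carbon gives a number 31 percentage points higher from compound 2 to compound 4 (beyond the scatter), so the outcome of that change depends on which pyridyl group is present: the same change on two cores in this assay, a number 5.8 percentage points lower (within the scatter) from compound 1 to compound 3 and a number 31 percentage points higher (beyond the scatter) from compound 2 to compound 4, 36.8 percentage points apart, beyond the scatter of two such steps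

The two changes therefore do not act independently in these four compounds, and only the combination of pyridin-2-yl with the methyl stands apart.

As far as these compounds go, whether this dependence persists with an ethyl group in place of the methyl, or with pyridin-4-yl or phenyl on the double-bonded chain carbon, remains open. Also open, from the compounds shown here alone, is whether the same separation would appear in a full concentration-response measurement rather than at a single concentration.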